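A few compounds are considered here, and "the series" means these few. Any claim that something is new, unique, unknown or untested is made for them only; others in the source may bear on it.

The measured compounds:

Compound 1, `O=C1/C(=C/c2ccccc2C(F)(F)F)CCc2ccc(O)cc21`. In a functional assay on RAW264.7 cells (Mus musculus) for inhibition (a higher number here means a weaker inhibitor, a lower number a stronger inhibitor), compound 1 gives 1020 nM.
Compound 2, `O=C1/C(=C/c2ccc(C(F)(F)F)cc2)CCc2ccc(O)cc21`. In this assay compound 2 gives only a limit and not a number, > 10000 nM, which is the limit of > 10000 nM in this assay, at which 1 of the 3 values shown sits.
Compound 3, `O=C1/C(=C/c2ccccc2OC(F)(F)F)CCc2ccc(O)cc21`. In this assay compound 3 gives 420 nM.

Compound 1 and compound 2 are made of the same atoms joined differently; the difference between the two cores is not broken down here. Compound 3 arises from compound 1 by one change, (trifluoromethoxy in place of trifluoromethyl on an aromatic carbon). That change made a 2.4-fold lower number from compound 1 to compound 3 (0.39 log units; beyond the scatter).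

Compound 4, `O=C1/C(=C/c2ccc(OC(F)(F)F)cc2)CCc2ccc(O)cc21`, has not yet been measured in this assay. It arises from compound 2 by the same kind of change, (trifluoromethoxy in place of trifluoromethyl on an aromatic carbon). The place is not the same word for word: in compound 1 the group sits ortho to a large group, in compound 2 para to a large group, so this is the same kind of change rather than the same change.

For compound 4 a step of an at least 1.2-fold lower number from compound 2 to compound 4 (0.09 log units; that floor lies within the scatter) is expected, resting on the step from compound 1 to compound 3, a 2.4-fold lower number from compound 1 to compound 3 (0.39 log units; beyond the scatter). The starting point is uncertain because compound 2 shows only a limit > 10000 nM, so compound 4 may itself be reported as a limit. Compound 4 is estimated at 8000 nM, with a likely range from 3000 nM to 30000 nM.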

Compound 4, half-maximal inhibitory concentration: 980 nM
Compound 4: middle estimate off by 8.2-fold (0.91 log units), on the high side; measured number outside the range, below it.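

In this assay, trifluoromethoxy in place of trifluoromethyl gives a lower number on both cores, so the direction of the change carries over from one core to the other, but its size does not: the same change on two cores in this assay, a 2.4-fold lower number (0.39 log units; beyond the scatter) from compound 1 to compound 3 and an at least 10-fold lower number (1.00 log units; beyond the scatter) from compound 2 to compound 4, at least 4.2-fold (0.62 log units) apart, beyond the scatter of two such steps

Compound 2 gives > 10000 nM, which is a limit of the assay and not a number. The step of an at least 10-fold lower number from compound 2 to compound 4 (1.00 log units; beyond the scatter) is thus only a floor on the true size, and the two pairs do not show why the steps differ: the group sits in a different place on the ring in each pair, so the effect of the core cannot be separated from the effect of that place.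

With only two pairs, this is no general rule for the series, and the compounds shown leave open whether the trifluoromethoxy group would give a similar step in any other place on the ring. They also leave open how other groups would compare with trifluoromethyl and trifluoromethoxy on the same ring, for example a methoxy group, a chlorine atom or a nitrile.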